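A Second Bromo on the Quinone Ring of Compound 2

The source may hold more compounds than are shown below. What is called first, only, known or untested is meant among the compounds shown, and "the series" means these compounds.

Measured in an ADME assay on cells (Peritoneal macrophage, Mus musculus, strain Swiss) for cytotoxicity, with a stated time of 24 h; a lower number here means that less compound is tolerated, a higher number that more compound is tolerated:
- Compound 1 `O=C1C=CC(=O)c2c1ccc(I)c2O` gives > 100000 nM (a limit)
- Compound 2 `O=C1C(Br)=CC(=O)c2c(I)cccc21` gives 12200 nM

Within the data shown here, only two readings are available, and just one of them is a number. For compound 1 the reading is > 100000 nM, which is a limit of the assay and not a number. Among the measured compounds shown here, compound 2 supplies the only number in this assay at 12200 nM and so serves as the reference for what follows.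

Compound 3 `O=C1C(Br)=C(Br)C(=O)c2c(I)cccc21` departs from compound 2 in a single place (bromo in place of hydrogen on a double-bonded ring carbon). It carries bromo in place of hydrogen on a double-bonded ring carbon, next to the ring atom that bears a bromo group. For the measured compounds named here, no pair of measured compounds shows this change, so the size of the step cannot be read from the data and remains a judgement. A moderate move toward less compound being tolerated is expected, and the estimated change is a 2.4-fold lower number from compound 2 to compound 3 (0.39 log units; beyond the scatter). In this assay the estimate for compound 3 is 5000 nM, with an expected range from 1500 nM to 15000 nM.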

Compound 3, concentration lethal to 50% of the cells: 11800 nM
Beside the measured number, compound 3's estimate is 2.4-fold (0.37 log units) below it, within the range that was stated.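

In this assay, bromo in place of hydrogen on a double-bonded ring carbon, next to the ring atom that bears a bromo group, gives a 1.0-fold lower number from compound 2 to compound 3 (0.01 log units; within the scatter). Among these compounds, this is the first step that can be read at this position, as the earlier compounds offered no pair differing in one place, and it shows that the ring carbon can carry a second bromo without a change in the number that stands out from the scatter. Compound 1 gives a limit and not a number, so it has no part in this comparison, and neither compound of the pair sits at that limit: the limit of > 100000 nM in this assay, at which 1 of the 3 values shown sits.

The compounds shown cover only hydrogen and bromo at this ring carbon, so this single step cannot say whether the flat result extends to other groups there, such as an amine, a methoxy group or a longer chain. They also leave open whether the same change would give the same result on a core with other substituents, since the step has been read only once and only in this one assay.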